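This account rests on a few compounds, and the source may have more. Where it says the series, first, only, none or still open, it means among the compounds named here.

Measured in an ADME assay on A549 cells (Homo sapiens) for cytotoxicity, read by resazurin assay, with a stated time of 48 h; a lower number here means that less compound is tolerated, a higher number that more compound is tolerated:
Compound 1 `CCCNc1ccc(NC(=O)c2cc(Cl)ccc2O)c(Cl)c1`: 22500 nM
Compound 2 `COc1ccc(CNc2ccc(NC(=O)c3cc(Cl)ccc3O)c(Cl)c2)cc1`: 80700 nM

Going by the values given here, compound 2 stands at 80700 nM, the highest of the two numbers so far. Among the compounds with values here, the only measured step is a 3.6-fold higher number from compound 1 to compound 2 (0.55 log units; beyond the scatter). It is modest and goes with 4-methoxyphenyl in place of ethyl on a saturated chain carbon bound to a nitrogen on an aromatic ring.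

Compound 3 `CN(C)c1ccc(CNc2ccc(NC(=O)c3cc(Cl)ccc3O)c(Cl)c2)cc1` has dimethylamino in place of methoxy on an aromatic carbon, para to a large group: dimethylamino in place of methoxy on an aromatic carbon. The same difference reads 4-methoxyphenyl to 4-(dimethylamino)phenyl. Within the data shown here, no measured step covers this exchange. The step of a 3.6-fold higher number from compound 1 to compound 2 (0.55 log units; beyond the scatter) bears on it only indirectly, since it concerns the group now being altered, and it suggests how far this assay can move in this series. A smaller change than that one is therefore expected, with no firm direction and only a slight lean downward. The expected change is a 1.3-fold lower number from compound 2 to compound 3 (0.13 log units; within the scatter). For compound 3 the estimated value is 60000 nM, with an expected range of 25000 nM to 130000 nM.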

Compound 3, half-maximal cytotoxic concentration: 24500 nM
Estimate against measurement, compound 3: 2.4-fold (0.39 log units) above, outside the stated range (below it).
By their numbers in this assay, from the lowest: compounds 1 and 3 (each within the scatter of the next); then compound 2.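

In this assay the group on the aromatic carbon, para to a large group, can move the number by itself: dimethylamino in place of methoxy gives a 3.3-fold lower number from compound 2 to compound 3 (0.52 log units; beyond the scatter) and thus shows that the 4-methoxyphenyl result in a 3.6-fold higher number from compound 1 to compound 2 (0.55 log units; beyond the scatter) does not carry over to every group of this kind. With 4-(dimethylamino)phenyl in place of ethyl on the saturated chain carbon, the comparison gives a 1.1-fold higher number from compound 1 to compound 3 (0.04 log units; within the scatter) and stays within the scatter, so of the two aromatic groups compared with ethyl, only 4-methoxyphenyl gives a separate number. No available measurement explains why methoxy and dimethylamino differ here.

A plain phenyl group without a substituent would show whether methoxy raises the number or dimethylamino lowers it, relative to the unsubstituted case. From the compounds shown here alone, it also remains open how a hydroxy group, a primary amine or a carboxylic acid on the same aromatic carbon would read in this assay and whether either of the two groups compared here would behave the same way on a longer chain.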